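Replacing cyclohexylamino with cyclohexylmethyl on a carbonyl carbon

The source may report more compounds than this note shows. Statements on the series, on what has been measured and on what is new or still open speak of the compounds shown alone.

Measured in a functional assay on HCT-116 cells (Homo sapiens) for antiproliferative activity, read by MTT assay, with a stated time of 72 h; a lower number here means a stronger inhibitor, a higher number a weaker inhibitor:
Compound 1 `O=C(Nc1ccc(Nc2nccc(NC3CC3)n2)cc1)Nc1ccc(Cl)c(C(F)(F)F)c1` gives 16400 nM
Compound 2 `O=C(Nc1ccc(Nc2nccc(Nc3ccccc3Cl)n2)cc1)Nc1ccc(Cl)c(C(F)(F)F)c1` gives 8100 nM
Compound 3 `O=C(Nc1ccc(Nc2nccc(NC3CCCC3)n2)cc1)NC1CCCCC1` gives 1090 nM

Compound 3 has the lowest number of these three, well beyond the scatter from the other two. Compound 4 `O=C(CC1CCCCC1)Nc1ccc(Nc2nccc(NC3CCCC3)n2)cc1` differs from it in one place, with cyclohexylmethyl in place of cyclohexylamino on a carbonyl carbon. Among the measured compounds shown here, no measured step covers this change. The only one available, a 2.0-fold lower number from compound 1 to compound 2 (0.31 log units; beyond the scatter), is modest and concerns a different place, 2-chlorophenyl in place of cyclopropyl on a nitrogen on an aromatic ring. It therefore gives no direct guide to size or direction. With nothing to point either way, no step beyond the scatter is expected in this assay, though the uncertainty is wide and leans towards a higher number. The estimate is a 1.4-fold higher number from compound 3 to compound 4 (0.14 log units; within the scatter), an expected shift that stays small. Compound 4 is expected to give about 1500 nM (estimated range 500 nM to 4500 nM).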

Compound 4, half-maximal inhibitory concentration: 2440 nM
Compound 4: middle estimate off by 1.6-fold (0.21 log units), on the low side; measured number inside the range.
By their numbers in this assay, from the lowest: compound 3; then compound 4; then compound 2; then compound 1.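

In this assay, among the compounds shown here, the step of a 2.2-fold higher number from compound 3 to compound 4 (0.35 log units; beyond the scatter) is the first measured at this position, on a carbonyl carbon, and it is modest but beyond the scatter. The two groups have the same number of heavy atoms and the same six-membered carbon ring; what changes is that a nitrogen is replaced by a carbon and one hydrogen-bond donor is lost. So this exchange, with the rest of the molecule unchanged, is accompanied by a higher number, though no evidence is available that accounts for the shift.

With only this single pair, the compounds shown leave open whether the same step would appear with other groups on the far side of the core, such as the cyclopropylamino group. They also leave open how a longer chain, a phenyl ring or a carboxylic acid at this carbonyl carbon would compare.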